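The compounds below may be only part of what the source reports. "The series", "measured", "known", "first", "only" and "open" are said of these compounds alone.

Measured so far:
- compound 1 `CC(C)NC(=O)[C@H](CCN1CCN(C)CC1)NC(=O)c1ccco1`: > 2000000 nM
- compound 2 `CC(C)NC(=O)[C@H](CCN1CCN(C)CC1)NC(=O)N1CCOCC1`: > 2000000 nM

In an ADME assay on CHO cells (Cricetulus griseus) for cytotoxicity (a higher number here means a weaker inhibitor, a lower number a stronger inhibitor), compound 1 gives > 2000000 nM, which is a limit of the assay, not a number. Compound 2 likewise gives > 2000000 nM, again a limit. The step that the two limits leave unreadable from compound 1 to compound 2 is therefore unreadable; both values sit at the limit of > 2000000 nM in this assay, at which 2 of the 2 values shown sit. Compound 3 `CC(C)NC(=O)[C@H](CCn1ccnc1)NC(=O)c1ccco1` differs from compound 1 by 1H-imidazol-1-yl in place of 4-methylpiperazin-1-yl on a saturated chain carbon, three bonds along the chain from an amide-type nitrogen and a carbonyl carbon. Among the measured compounds shown here, no measured step bears on this change, and the one step in the set gives no size. Compound 3 is expected to remain at the limit, with a number no higher from compound 1 to compound 3 (the limit leaves the size open) expected to be no step beyond the scatter. The estimate for compound 3 is 2000000 nM, between 1000000 nM and 4000000 nM.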

Compound 3, half-maximal inhibitory concentration: 546000 nM
Compound 3: the middle estimate sits 3.7-fold (0.56 log units) above what was measured, and the stated range ends above it.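

In this assay, the group on the saturated chain carbon, three bonds along the chain from an amide-type nitrogen and a carbonyl carbon, proves able to move the read-out: the change gives an at least 3.6-fold lower number from compound 1 to compound 3 (0.56 log units; beyond the scatter). Among the compounds shown here, compound 3 thus holds the only value shown that is a number rather than a limit. The full size of the step stays open because compound 1 stands at a limit: the limit of > 2000000 nM in this assay, at which 2 of the 3 values shown sit.

Still open, on these data alone, is whether a primary amine or a carboxylic acid at this position would shift the number further. As far as these compounds go, it is also open whether 1H-imidazol-1-yl has a similar effect with morpholin-4-yl in place of furan-2-yl on the carbonyl carbon.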